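Replacing fluoro with methoxy on compound 2

The compounds below may be only part of what the source reports. "The series", "measured", "known", "first", "only" and "open" are said of these compounds alone.

Measured in a functional assay on MCF7 cells (Homo sapiens) for antiproliferative activity, with a stated time of 5 days; a higher number here means a weaker inhibitor, a lower number a stronger inhibitor:
- compound 1 `CCCCc1ccc2[nH]c(-c3ccc(OC)cc3)c(/C=N/O)c2c1`: 212 nM
- compound 2 `CCCCc1ccc2[nH]c(-c3ccc(OC)cc3)c(/C=N/NC(=O)c3ccc(F)cc3)c2c1`: 84 nM

Compound 2 holds the lower of the two numbers, which makes it the stronger inhibitor of this pair. Compound 3 `CCCCc1ccc2[nH]c(-c3ccc(OC)cc3)c(/C=N/NC(=O)c3ccc(OC)cc3)c2c1` differs from it in one place: methoxy in place of fluoro on an aromatic carbon. Methoxy takes the place of fluoro on an aromatic carbon, para to a large group.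

Among the compounds with values here, only one measured step exists, a 2.5-fold lower number from compound 1 to compound 2 (0.40 log units; beyond the scatter). This modest step swapped hydroxy on a double-bonded nitrogen for ((4-fluorophenyl)carbonyl)amino, so it leaves the fluoro untested. No measurement shows what changing fluoro does, and the data give no firm direction. A step beyond the scatter is therefore not expected in this assay. The expected step is a 1.2-fold higher number from compound 2 to compound 3 (0.08 log units; within the scatter), and the wide range reflects this thin evidence. For compound 3 the estimate is 100 nM, with an expected range from 40 nM to 250 nM.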

Compound 3, half-maximal inhibitory concentration: 226 nM
Beside the measured number, compound 3's estimate is 2.3-fold (0.35 log units) below it, and the stated range covers the measured number.
By their numbers in this assay, from the lowest: compound 2; then compounds 1 and 3 (each within the scatter of the next).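

In this assay, the first test of this place shows that the group on this aromatic carbon matters: methoxy in place of fluoro gives a 2.7-fold higher number from compound 2 to compound 3 (0.43 log units; beyond the scatter). The earlier step could not show that the gain over hydroxy depends on this group, but with ((4-methoxyphenyl)carbonyl)amino in place of hydroxy the result is a 1.1-fold higher number from compound 1 to compound 3 (0.03 log units; within the scatter), so these two compounds cannot be told apart in this assay. The data shown offer no measurement that explains this difference between fluoro and methoxy.

From the compounds shown here alone, whether chloro, methyl or an amine on this aromatic carbon would give a number closer to that of compound 2 or of compound 3 remains open. Going by these compounds, it is also open whether the same swap would give a step of similar size with a longer chain on the shared core.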